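Adding a Third Fluoro to the Aryl Ether

The source may report more compounds than this note shows. Statements on the series, on what has been measured and on what is new or still open speak of the compounds shown alone.

Compound 1 `Fc1ccc(Oc2ncnc3[nH]ccc23)c(F)c1` gives 710 nM in an assay on HEK293-TREx cells for antagonist activity at transient receptor potential cation channel subfamily A member 1 (Homo sapiens), read by fluorescence and calcium flux, with a stated time of 72 h; on this read-out higher numbers stand for weaker inhibition and lower numbers for stronger inhibition. Among the compounds with values here, of the two numbers measured so far, this is the higher one, yet compound 3 `Fc1ccc(Oc2ncnc3[nH]cc(Cl)c23)c(F)c1` with 630 nM sits very close, and the step of a 1.1-fold lower number from compound 1 to compound 3 (0.05 log units; within the scatter) stays within the scatter. Compound 2 `Fc1ccccc1Oc1ncnc2[nH]ccc12` reaches only the limit of > 32000 nM in this assay, so no number is known for it. The step of an at least 45-fold higher number from compound 1 to compound 2 (1.65 log units; beyond the scatter), where one fluoro was taken away, is large. Compound 4 `Fc1cc(F)c(Oc2ncnc3[nH]ccc23)c(F)c1` differs from compound 1 by fluoro in place of hydrogen on an aromatic carbon. Within the data shown here, no measured step adds a fluoro, but since removing one was so costly, a modest gain is expected, a 1.8-fold lower number from compound 1 to compound 4 (0.25 log units; within the scatter). Compound 4 is therefore estimated at 400 nM, between 100 nM and 2000 nM.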

Compound 4, half-maximal inhibitory concentration: > 32000 nM
Compound 4 ended at the assay's limit; the forecaster's own chance of this, stated with the estimate: 5%; at least 80-fold (1.90 log units) between middle value and limit.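

Putting a fluoro on this aromatic carbon, ortho to a large group, brings a large loss of inhibition: an at least 45-fold higher number from compound 1 to compound 4 (1.65 log units; beyond the scatter). Until now only taking a fluoro away had shown such a loss; now adding one does too, so among these compounds more fluoro does not mean stronger inhibition. The value of compound 4 is a limit and not a number, so the full size of the step is unknown: the limit of > 32000 nM in this assay, at which 2 of the 4 values shown sit.

From the compounds shown here alone, whether a methyl or a methoxy group on this carbon would also lose inhibition stays open. The compounds shown also leave open why the added fluoro costs so much.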